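Compound 3 to compound 4: a new carbonyl substituent

The compounds below may be only part of what the source reports. "The series", "measured", "known", "first", "only" and "open" are said of these compounds alone.

Measured so far in a physicochemical assay for solubility; on this read-out higher numbers stand for higher solubility and lower numbers for lower solubility:
- compound 1 `CC(C)(O)CCN1CCC(NS(=O)(=O)c2cc(S(=O)(=O)c3ccccc3)ccc2C(F)(F)F)CC1` gives 50000 nM
- compound 2 `CC(C)(C)OC(=O)N1CCC[C@H]1C(=O)N1CCC(NS(=O)(=O)c2cc(S(=O)(=O)c3ccccc3)ccc2C(F)(F)F)CC1` gives 25000 nM
- compound 3 `O=C(CC1CCNCC1)N1CCC(NS(=O)(=O)c2cc(S(=O)(=O)c3ccccc3)ccc2C(F)(F)F)CC1` gives 100000 nM

Compound 3 (100000 nM) sits within the scatter of compound 1 and clear of compound 2 only. Compound 4 `O=C([C@H]1CCNC1)N1CCC(NS(=O)(=O)c2cc(S(=O)(=O)c3ccccc3)ccc2C(F)(F)F)CC1` carries pyrrolidin-3-yl in place of (piperidin-4-yl)methyl on a carbonyl carbon. Within the data shown here, no measured step makes this exact change. Among the measured compounds shown here, two steps bear on it indirectly: a 2.0-fold higher number from compound 1 to compound 3 (0.30 log units; within the scatter), and, at the same carbonyl carbon, a 4.0-fold higher number from compound 2 to compound 3 (0.60 log units; beyond the scatter). The second is modest and the first stays within the scatter, so no step beyond the scatter is expected in this assay. The expected step is a 1.3-fold lower number from compound 3 to compound 4 (0.10 log units; within the scatter). Compound 4 is estimated at 80000 nM, with an expected range of 35000 nM to 160000 nM.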

Compound 4, solubility: 25000 nM
Beside the measured number, compound 4's estimate is 3.2-fold (0.51 log units) above it, and the stated range ends above it.
By their numbers in this assay, from the lowest: compounds 2, 4, 1 and 3 (each within the scatter of the next, the first and the last beyond it).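

In this assay, this change at the carbonyl carbon gives the first step measured at this place from compound 3 with a simple amine-bearing ring on both sides (a 4.0-fold lower number from compound 3 to compound 4 (0.60 log units; beyond the scatter)), so the pyrrolidin-3-yl group does not match (piperidin-4-yl)methyl here. Compound 4 cannot be told apart from the other two (no change at the digits printed from compound 2 to compound 4 (within the scatter); a 2.0-fold lower number from compound 1 to compound 4 (0.30 log units; within the scatter)). Nothing measured here accounts for the step.

Still open, going by these compounds, is which part of the change matters: the ring size, the methyl link or the defined stereocentre. The opposite stereoisomer of pyrrolidin-3-yl, or piperidin-4-yl directly on the carbonyl, would separate these.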